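Trimming a Pyridinyl Amide Down to a Methyl Group

The source may report more compounds than this note shows. Statements on the series, on what has been measured and on what is new or still open speak of the compounds shown alone.

Compound 1 `CCCCc1nc(=O)c(S(=O)(=O)c2ccc(-c3ccnc(NC(=O)C4CC4)c3)cc2)c(O)n1-c1c(OC)cccc1OC`: 11 nm/s
Compound 2 `CCCCc1[nH]c(=O)c(S(=O)(=O)c2ccc(-c3ccncc3C)cc2)c(O)c1-c1c(OC)cccc1OC`: 76 nm/s
Compound 3 `CCCCc1[nH]c(=O)c(S(=O)(=O)c2ccc(-n3cc(Cl)ccc3=O)cc2)c(O)c1-c1c(OC)cccc1OC`: 22 nm/s

In an ADME assay for permeability, using PAMPA, at pH 7.4 (on this read-out higher numbers stand for higher permeability and lower numbers for lower permeability), compound 1 gives the lowest of the three numbers. Its nearest neighbour is compound 3, whose value sits within the scatter of that of compound 1, while compound 2 lies further off, beyond the scatter. Compound 4 `CCCCc1nc(=O)c(S(=O)(=O)c2ccc(C)cc2)c(O)n1-c1c(OC)cccc1OC` keeps the shared core of compound 1 and changes only one place: methyl in place of 2-((cyclopropylcarbonyl)amino)pyridin-4-yl on an aromatic carbon.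

For the measured compounds named here, no measured pair covers this particular exchange. Going by the values given here, the one step that can be read, a 3.5-fold lower number from compound 2 to compound 3 (0.54 log units; beyond the scatter), concerns a different core and a different pair of groups, so it tells only that swapping the group at this position can shift the read-out by a modest amount in either direction. Given that, and given that compound 1 carries the largest and most donor-rich group of the set yet sits at the bottom in this assay, the expectation for compound 4 is a rise rather than a fall, of a size similar to the one step seen, but with wide uncertainty. Compound 4 is therefore estimated at 40 nm/s, with a range from 12 nm/s to 130 nm/s, which corresponds to an expected step of a 3.6-fold higher number from compound 1 to compound 4 (0.56 log units; beyond the scatter).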

Compound 4, apparent permeability: 7 nm/s
The estimate for compound 4 lay 5.7-fold (0.76 log units) above the measured number, and the stated range ends above it.
By their numbers in this assay, from the lowest: compounds 4, 1 and 3 (each within the scatter of the next, the first and the last beyond it); then compound 2.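

In this assay, replacing the 2-((cyclopropylcarbonyl)amino)pyridin-4-yl group with methyl gives a 1.6-fold lower number from compound 1 to compound 4 (0.20 log units; within the scatter), so on the shared core these two groups cannot be told apart. The exchange strips out both rings of that group, its amide, its hydrogen-bond donor and its hydrogen-bond acceptors, yet the two compounds stay within the scatter of each other, which means that on this core, for this one pair, the size of the group on this aromatic carbon does not track the read-out. Nothing measured here accounts for this lack of separation.

A carboxylic acid or a primary amine on this aromatic carbon would test the position with a small group of a different kind, and the compounds shown leave open whether either would move the read-out beyond the scatter on the shared core. For the compounds shown here, also open is whether the same exchange to methyl would leave the number unmoved on the different core carried by compound 2 and compound 3, since no pair on that core covers it.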